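Working notes: amide-nitrogen substituent in the tricyclic series

The source may report more compounds than this note shows. Statements on the series, on what has been measured and on what is new or still open speak of the compounds shown alone.

All values come from a functional assay on A-375 cells (Homo sapiens) for antiproliferative activity, read by MTT assay, with a stated time of 72 h; on this read-out lower numbers stand for stronger inhibition and higher numbers for weaker inhibition.

Compound 1 `COc1cccc(N2C(=O)COc3ccc(-c4cnc(OC)c(NS(=O)(=O)c5ccc(F)cc5)c4)cc32)c1`: compound 1 gives > 40000 nM, a limit of the assay.
Compound 2 `COc1ncc(-c2ccc3c(c2)N(C2CCCCC2)C(=O)CO3)cc1NS(=O)(=O)c1ccc(F)cc1`: compound 2 gives > 40000 nM, a limit of the assay.
Compound 3 `COc1cccc(N2C(=O)COc3ccc(-c4cnc5ccccc5c4)cc32)c1`: compound 3 gives 23600 nM.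

Two of the three values sit at the limit (the limit of > 40000 nM in this assay, at which 2 of the 3 values shown sit), so the step that the two limits leave unreadable from compound 1 to compound 2 cannot be read in either direction. Among the compounds with values here, compound 3 supplies the only number in this assay. The difference between the core of compound 1 and the core of compound 3 is not broken down here.

Compound 4 `O=C1COc2ccc(-c3cnc4ccccc4c3)cc2N1C1CCCCC1` is not yet measured. It differs from compound 3 by cyclohexyl in place of 3-methoxyphenyl on an amide-type nitrogen in a ring. This is the same change as cyclohexyl in place of 3-methoxyphenyl on an amide-type nitrogen in a ring between compound 1 and compound 2, at a place described in the same words.

With compound 3 already weak at 23600 nM and the earlier instance of this change unreadable, the expected step of a 1.9-fold higher number from compound 3 to compound 4 (0.28 log units; within the scatter) is taken as small or toward weaker inhibition. Compound 4 is therefore estimated at 45000 nM, within 15000 nM to 150000 nM, with a fair chance that only a limit is reported.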

Compound 4, half-maximal inhibitory concentration: > 40000 nM
Compound 4: a limit, no number; the forecaster's own chance of this, stated with the estimate: 55%; the middle value lies beyond the limit too.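

In this assay, on these data alone, placing cyclohexyl instead of 3-methoxyphenyl on the amide-type nitrogen of the core of compound 3 gives an at least 1.6-fold higher number from compound 3 to compound 4 (0.22 log units; that floor lies within the scatter), so only a floor on the size of this step can be read, and the true size remains unknown. On the core of compound 1 the same change cannot be read, so there is no second size to set beside this one, and the data neither confirm nor refute that the change carries from one core to the other. Any finer reading of the series is capped by the assay limit: the limit of > 40000 nM in this assay, at which 3 of the 4 values shown sit.

The compounds shown leave open whether any other group on the amide-type nitrogen, such as methyl, a benzyl group or a short chain ending in an amine or a carboxylic acid, would give a number on either core. Within the data shown here, they also leave open how far 3-methoxyphenyl itself contributes to the only number available, that of compound 3.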